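Moving a methoxy group around the aryl ring

The compounds below may be only part of what the source reports. "The series", "measured", "known", "first", "only" and "open" are said of these compounds alone.

Compound 2 `COc1cc(-c2nc3cc(/C=C4\SC(=O)N(Cc5cccc(C)c5)C4=O)ccc3[nH]2)cc(OC)c1OC` is measured in a functional assay on A549 cells (Homo sapiens) for inhibition, read by MTT assay, with a stated time of 48 h (a higher number here means a weaker inhibitor, a lower number a stronger inhibitor), and gives 930 nM. Its only companion, compound 1 `COc1cc(OC)c(-c2nc3cc(/C=C4\SC(=O)N(CC(=O)N5CCOCC5)C4=O)ccc3[nH]2)cc1OC`, gives 660 nM in this assay; the two numbers lie within the usual scatter of each other, so neither can be called the stronger. Compound 3 `COc1cc(OC)c(-c2nc3cc(/C=C4\SC(=O)N(Cc5cccc(C)c5)C4=O)ccc3[nH]2)cc1OC` is not yet measured. It differs from compound 2 only in that (2,4,5-trimethoxyphenyl in place of 3,4,5-trimethoxyphenyl on an aromatic carbon). Among the compounds with values here, no measured pair shows the effect of such a rearrangement, so the step of a 1.0-fold lower number from compound 2 to compound 3 (0.01 log units; within the scatter) is expected to stay within the scatter, in no particular direction. Compound 3 is therefore estimated at 900 nM, with a range from 350 nM to 2500 nM.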

Compound 3, half-maximal inhibitory concentration: 130 nM
Compound 3: the middle estimate sits 6.9-fold (0.84 log units) above what was measured, outside the stated range (below it).
By their numbers in this assay, from the lowest: compound 3; then compounds 1 and 2 (each within the scatter of the next).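

In this assay, the aromatic carbon of the five-membered ring is sensitive to how the three methoxy groups are arranged: with the same atoms throughout, 2,4,5-trimethoxyphenyl in place of 3,4,5-trimethoxyphenyl gives a 7.2-fold lower number from compound 2 to compound 3 (0.85 log units; beyond the scatter). The second site matters too, since 3-methylphenyl in place of (morpholin-4-yl)carbonyl, on a saturated chain carbon bound to an amide-type nitrogen in a ring, gives a 5.1-fold lower number from compound 1 to compound 3 (0.71 log units; beyond the scatter). Nothing measured here explains either step. Within the data shown here, it remains open whether a phenyl ring with only one methoxy group, or with a chlorine atom or hydroxyl group instead, would keep this strength. A basic amine on that chain is equally untested in these compounds.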